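The compounds below may be only part of what the source reports. "The series", "measured", "known", "first", "only" and "open" are said of these compounds alone.

Measured compounds:
Compound 1 `COc1cc(/C=C/C(=O)/C=C(/C=C/c2ccc(OC(C)=O)c(OC)c2)NC2CCCCC2)ccc1OC(C)=O`: in an ADME assay on Caco-2 cells (Homo sapiens) for inhibition, read by MTT assay, with a stated time of 72 h (on this read-out lower numbers stand for stronger inhibition and higher numbers for weaker inhibition), compound 1 gives > 25000 nM, which is a limit of the assay, not a number.
Compound 2 `COc1cc(/C=C/C(=O)/C=C(/C=C/c2ccc(OC(C)=O)c(OC)c2)NCC(C)C)ccc1OC(C)=O`: in this assay compound 2 gives > 25000 nM, again a limit.
Compound 3 `COc1cc(/C=C/C(=O)/C=C(/C=C/c2ccc(O)c(OC)c2)NC2CCCCC2)ccc1O`: in this assay compound 3 gives > 25000 nM, again a limit.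

Compounds 1 and 2 share one core and differ only by isobutyl in place of cyclohexyl on an amine nitrogen. The step that the two limits leave unreadable from compound 1 to compound 2 stays unreadable because of the limit of > 25000 nM in this assay, at which 3 of the 3 values shown sit. Compound 3 carries a different core; how the cores of compound 1 and compound 3 differ is not broken down here. Compound 4 `COc1cc(/C=C/C(=O)/C=C(/C=C/c2ccc(O)c(OC)c2)NCC(C)C)ccc1O` has not yet been measured and differs from compound 3 by isobutyl in place of cyclohexyl on an amine nitrogen, the same change at the same kind of place. Since the earlier pair gave no readable step, the step that the limit leaves unreadable from compound 3 to compound 4 is expected to be equally flat, resting on a step that the two limits leave unreadable from compound 1 to compound 2. For compound 4 in this assay a value near 40000 nM is expected, between 20000 nM and 150000 nM, most probably reported only as a limit.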

Compound 4, half-maximal inhibitory concentration: > 25000 nM
Compound 4: only a limit was reported (the forecaster's own chance of this, stated with the estimate: 85%); the middle value does not contradict the limit.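

No step can be read from compound 3 to compound 4, because both values are limits of the assay, not numbers: the limit of > 25000 nM in this assay, at which 4 of the 4 values shown sit. The compounds shown leave open how strongly any of them acts in this assay and whether isobutyl in place of cyclohexyl changes that.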